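This account rests on a few compounds, and the source may have more. Where it says the series, first, only, none or still open, it means among the compounds named here.

Compound 1 `COc1ccc(N2C(=O)CSC2c2sc(-c3ccccc3)nc2C)cc1` was tested in a functional assay on the whole organism (strain Wistar albino) for inhibition, with Rattus norvegicus as the target, read by paw edema, with a stated time of 1 h, at a dose of 40 mg/kg by the oral route (a lower number here means less inhibition, a higher number more inhibition at the dose given (going by the name of the read-out)), where compound 1 gives 52.3%. It stands second highest of three numbers: compound 2 `Cc1nc(-c2ccccc2)sc1C1SCC(=O)N1c1ccc(F)c(Cl)c1` gives 55.9% and compound 3 `Cc1nc(Cc2ccc(Cl)cc2)sc1C1SCC(=O)N1c1ccc(Cl)cc1` gives 48.9%, both within the scatter of compound 1. Among the compounds with values here, the single measured step, a number 3.6 percentage points higher from compound 1 to compound 2 (within the scatter), changes the group on the amide-type nitrogen of the shared core and lies within the scatter. Compound 4 `COc1ccc(N2C(=O)CSC2c2sc(-c3ccc(Cl)cc3)nc2C)cc1` differs from compound 1 by chloro in place of hydrogen on an aromatic carbon. Within the data shown here, no measured step touches this part of the shared core, so nothing in the data points to a change beyond the scatter, and compound 4 is expected to give 53%, between 40% and 66%. The expected step is a number 0.7 percentage points higher from compound 1 to compound 4 (within the scatter).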

Compound 4, a percentage reported as inhibition, in the whole organism at one dose (the size of the read-out at that dose, not a potency): 54%
Estimate against measurement, compound 4: 1 percentage points below, and the stated range covers the measured number.
By their numbers in this assay, from the lowest: compounds 3, 1, 4 and 2 (each within the scatter of the next).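

In this assay, within the data shown here, the measured step of a number 1.7 percentage points higher from compound 1 to compound 4 (within the scatter) is the first to touch the phenyl on the shared core, changing it to 4-chlorophenyl. A chloro in place of hydrogen at this position, para to a large group, thus stays within the scatter, something the earlier step on the amide-type nitrogen could not show. No supporting evidence bears on this result. From the compounds shown here alone, whether a carboxylic acid or an amine at this same place would also stay within the scatter remains open.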